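Swapping Chloro for Fluoro on the Shared Core

The compounds below may be only part of what the source reports. "The series", "measured", "known", "first", "only" and "open" are said of these compounds alone.

Measured compounds:
compound 1 `COC(=O)[C@@]1(C)CCC=C2[C@@H]1CC[C@@H](C)[C@]2(C)Cc1c[nH]c2ccccc12`: 8700 nM
compound 2 `COC(=O)[C@@]1(C)CCC=C2[C@@H]1CC[C@@H](C)[C@]2(C)Cc1c[nH]c2ccc(C)cc12`: 22000 nM
compound 3 `COC(=O)[C@@]1(C)CCC=C2[C@@H]1CC[C@@H](C)[C@]2(C)Cc1c[nH]c2ccc(Cl)cc12`: 20000 nM

In a functional assay on WiDr cells (Homo sapiens) for inhibition, read by sulforhodamine B assay, with a stated time of 48 h (a higher number here means a weaker inhibitor of growth, a lower number a stronger inhibitor of growth), compound 3 holds the second highest of the three numbers; its gap to compound 2 lies within the scatter, while the step of a 2.3-fold higher number from compound 1 to compound 3 (0.36 log units; beyond the scatter) is modest but beyond it. Compound 4 `COC(=O)[C@@]1(C)CCC=C2[C@@H]1CC[C@@H](C)[C@]2(C)Cc1c[nH]c2ccc(F)cc12` differs from compound 3 by fluoro in place of chloro on an aromatic carbon. Going by the values given here, two measured steps bear on this: a 2.5-fold higher number from compound 1 to compound 2 (0.40 log units; beyond the scatter) and a 2.3-fold higher number from compound 1 to compound 3 (0.36 log units; beyond the scatter) both show that a group on this carbon raises the number modestly, and a 1.1-fold lower number from compound 2 to compound 3 (0.04 log units; within the scatter) shows chloro and methyl within the scatter of each other. Fluoro is another such group, so compound 4 is expected to sit near compound 3, perhaps slightly lower, a step of a 1.3-fold lower number from compound 3 to compound 4 (0.12 log units; within the scatter). The estimate for compound 4 is 15000 nM, with a range of 7000 nM to 32000 nM.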

Compound 4, concentration for 50% growth inhibition: 8000 nM
Estimate against measurement, compound 4: 1.9-fold (0.27 log units) above; the range from low to high includes it.
By their numbers in this assay, from the lowest: compounds 4 and 1 (each within the scatter of the next); then compounds 3 and 2 (each within the scatter of the next).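

In this assay, a group on this carbon does not always go with a higher number: a 1.1-fold lower number from compound 1 to compound 4 (0.04 log units; within the scatter), which leaves fluoro level with the hydrogen within the scatter. Fluoro also stands apart from the two larger groups, with a 2.5-fold lower number from compound 3 to compound 4 (0.40 log units; beyond the scatter) and a 2.8-fold lower number from compound 2 to compound 4 (0.44 log units; beyond the scatter). Which group sits here therefore matters, not merely whether one is present.

Nothing measured here explains why fluoro parts from chloro and methyl. As far as these compounds go, whether an amine or a methoxy group on this carbon would fall with fluoro and hydrogen, or with chloro and methyl, remains open.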